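Nitro for chloro, carried from one core to the other

The source may report more compounds than this note shows. Statements on the series, on what has been measured and on what is new or still open speak of the compounds shown alone.

Measured so far:
compound 1 `O=C1NC(=O)/C(=C/c2cc(Cl)ccc2OCN2C(=O)c3ccccc3C2=O)S1`: > 100000 nM, a limit of the assay
compound 2 `O=C1NC(=O)/C(=C/c2cc([N+](=O)[O-])ccc2OCN2C(=O)c3ccccc3C2=O)S1`: 50500 nM
compound 3 `O=C1NC(=S)S/C1=C\c1cc(Cl)ccc1OCN1C(=O)c2ccccc2C1=O`: 34800 nM

All numbers come from an assay on isolated protein for inhibition of Alpha glucosidase (Homo sapiens), read by spectrophotometry, with stated times of 15 min and 30 min; on this read-out lower numbers stand for stronger inhibition and higher numbers for weaker inhibition. The value of compound 1 is a limit only; this is the limit of > 100000 nM in this assay, at which 1 of the 3 values shown sits, so the step to compound 2 is a floor, an at least 1.9-fold lower number from compound 1 to compound 2 (0.29 log units; that floor lies within the scatter), the change being (nitro in place of chloro on an aromatic carbon). The change of core, (a group of 8 heavy atoms (4 carbon, 1 nitrogen, 1 oxygen, 2 sulfur; one five-membered non-aromatic ring with 2 hetero atoms) in place of a group of 8 heavy atoms (4 carbon, 1 nitrogen, 2 oxygen, 1 sulfur; one five-membered non-aromatic ring with 2 hetero atoms), on an aromatic carbon), gives an at least 2.8-fold lower number from compound 1 to compound 3 (0.45 log units; beyond the scatter). Compound 3 and compound 2 are within the scatter of each other, so no order between them is read.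

Compound 4 `O=C1NC(=S)S/C1=C\c1cc([N+](=O)[O-])ccc1OCN1C(=O)c2ccccc2C1=O` is not yet measured. It differs from compound 3 by nitro in place of chloro on an aromatic carbon, the same change as from compound 1 to compound 2, placed word for word alike. On the core of compound 1 that change gave only a floor, an at least 1.9-fold lower number from compound 1 to compound 2 (0.29 log units; that floor lies within the scatter), so the expected step on the core of compound 3 is a 1.7-fold lower number from compound 3 to compound 4 (0.24 log units; within the scatter), of that order. For compound 4 the estimate in this assay is 20000 nM, expected to lie between 8000 nM and 50000 nM.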

Compound 4, half-maximal inhibitory concentration: 35800 nM
Estimate against measurement, compound 4: 1.8-fold (0.25 log units) below; low and high end bracket the measured number.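

In this assay, nitro in place of chloro gives a 1.0-fold higher number from compound 3 to compound 4 (0.01 log units; within the scatter), and the change of core with nitro held in place gives a 1.4-fold lower number from compound 2 to compound 4 (0.15 log units; within the scatter), so both steps lie within the scatter and no order is read across either pair. This does not show that nitro in place of chloro behaves differently on the two cores, nor that it behaves alike, and the comparison stays unresolved: the same change on two cores in this assay, an at least 1.9-fold lower number (0.29 log units; that floor lies within the scatter) from compound 1 to compound 2 and a 1.0-fold higher number (0.01 log units; within the scatter) from compound 3 to compound 4; the limit leaves it open whether they differ The change of core, set beside its earlier step, likewise cannot be said to depend on whether chloro or nitro is present: the same change on two cores in this assay, an at least 2.8-fold lower number (0.45 log units; beyond the scatter) from compound 1 to compound 3 and a 1.4-fold lower number (0.15 log units; within the scatter) from compound 2 to compound 4; the limit leaves it open whether they differ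

Going by these compounds, compound 1 stands at a limit of the assay, so the true size of both steps starting from it remains open: the limit of > 100000 nM in this assay, at which 1 of the 4 values shown sits. Also open is whether an amine, a carboxylic acid or a longer chain on that same aromatic carbon would give a number beyond the scatter of these values on either core.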